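A few compounds are considered here, and "the series" means these few. Any claim that something is new, unique, unknown or untested is made for them only; others in the source may bear on it.

Of the compounds shown here, three on a shared core have been read so far in a functional assay on MCF7 cells (Homo sapiens) for inhibition, read by MTT assay, with a stated time of 48 h, tested at 10 uM (a higher number here means more inhibition of growth at the concentration tested, a lower number less inhibition of growth), and they spread widely. Compound 1 (`Cc1cc(=O)c2c(O)cc(OCc3ccc([N+](=O)[O-])cc3)c([C@H]3CCN(C)C[C@H]3O)c2o1`) gives 39% of inhibition, compound 2 (`Cc1cc(=O)c2c(O)cc(OC/C=C/c3ccccc3)c([C@H]3CCN(C)C[C@H]3O)c2o1`) gives 7% of inhibition, and compound 3 (`CCN(CC)Cc1c(O)c([C@H]2CCN(C)C[C@H]2O)c2oc(C)cc(=O)c2c1O`) gives 24% of inhibition. Compound 3 therefore stands second of the three, under compound 1 and over compound 2.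

Compound 4 (`Cc1cc(=O)c2c(O)c(CN3CCCC3)c(O)c([C@H]3CCN(C)C[C@H]3O)c2o1`) has not yet been measured. It differs from compound 3 in one place, with pyrrolidin-1-yl in place of diethylamino on a saturated chain carbon bound to an aromatic carbon.

Among the compounds with values here, only one measured step links two compounds that differ in a single place (a number 32 percentage points lower from compound 1 to compound 2 (beyond the scatter)). That step is large, so one change on this core can move the number far. However, it concerns a different group at a different place, and no measured step touches diethylamino. As far as these compounds go, for this swap, no step beyond the usual scatter is expected in this assay as the best guess, although a wide range stays open in both directions. The estimated step (a number 1 percentage points higher from compound 3 to compound 4 (within the scatter)) is therefore small. The estimate for compound 4 is 25% (expected range 10% to 42%).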

Compound 4, percent growth inhibition at one concentration: 12%
For compound 4 the middle estimate is 13 percentage points above the measured one; the measured number falls inside the stated range.
By their numbers in this assay, from the lowest: compounds 2 and 4 (each within the scatter of the next); then compound 3; then compound 1.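

In this assay, within the data shown here, the step of a number 12 percentage points lower from compound 3 to compound 4 (beyond the scatter) is the first measured change at this place, a saturated chain carbon bound to an aromatic carbon, and it shows that the number responds to the amine held there. Diethylamino and pyrrolidin-1-yl have the same count of heavy atoms, the same carbon and nitrogen content and the same count of hydrogen-bond acceptors, and the printed difference between them is the five-membered non-aromatic ring in pyrrolidin-1-yl, so a step beyond the usual scatter can arise here without any change in those counts. No measured property of these compounds accounts for the size or direction of this step.

The compounds shown leave open whether other cyclic amines at this place, such as piperidin-1-yl or morpholin-4-yl, would read closer to compound 3 or to compound 4. They also leave open whether dimethylamino, a smaller open-chain amine, would read closer to compound 3, which would help show whether the ring itself or the particular amine matters more.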